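The compounds below may be only part of what the source reports. "The series", "measured", "known", "first", "only" and "open" are said of these compounds alone.

Measured compounds in a functional assay on BT-549 cells (Homo sapiens) for cytotoxicity, read by sulforhodamine B assay, with a stated time of 72 h; a lower number here means a stronger inhibitor, a higher number a weaker inhibitor:

Compound 1 `CCS(=O)(=O)Nc1cc(-c2ccc3ncnc(Nc4ccc(OC)cc4)c3c2)cnc1OC`: in this assay compound 1 gives 1880 nM.
Compound 2 `CCCCS(=O)(=O)Nc1cc(-c2ccc3ncnc(Nc4ccc(F)c(Cl)c4)c3c2)cnc1OC`: in this assay compound 2 gives 56800 nM.
Compound 3 `COC(=O)c1cccc(Nc2ncnc3ccc(-c4cnc(OC)c(NS(=O)(=O)c5ccc(F)cc5F)c4)cc23)c1`: in this assay compound 3 gives 12700 nM.

Compound 1 stands with the lowest number of the three. Compound 3 gives a higher number, and the gap between compound 1 and compound 3 is beyond the scatter; compound 2 gives a higher number still, and that gap is also beyond the scatter. Compound 2 and compound 3 each differ from compound 1 in more than one place, so no single change among the measured compounds can be read on its own.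

Compound 4 `CCS(=O)(=O)Nc1cc(-c2ccc3ncnc(Nc4ccc(F)nc4)c3c2)cnc1OC` has not been measured. It differs from compound 1 only at one place: 6-fluoropyridin-3-yl in place of 4-methoxyphenyl on a nitrogen on an aromatic ring. Within the data shown here, no measured pair shows this change, so the expected step rests on compound 1 alone.

The step from compound 1 to compound 4 is expected to be small, toward a higher number, and possibly not beyond the scatter: a 1.7-fold higher number from compound 1 to compound 4 (0.23 log units; within the scatter). For compound 4 the estimated value in this assay is 3200 nM, with an expected range from 900 nM to 11000 nM.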

Compound 4, half-maximal inhibitory concentration: 4780 nM
Compound 4: the middle estimate sits 1.5-fold (0.17 log units) below what was measured; measured number inside the range.
By their numbers in this assay, from the lowest: compound 1; then compound 4; then compound 3; then compound 2.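

The aromatic group on the nitrogen now has its first single-change reading: in this assay, 6-fluoropyridin-3-yl in place of 4-methoxyphenyl gives a 2.5-fold higher number from compound 1 to compound 4 (0.41 log units; beyond the scatter) with the rest of compound 1 held fixed. The step is beyond the scatter but modest, so this position does respond to the change, and the number moves only this far even though the ring and its substituent are replaced together. Among these compounds, the one step does not explain this shift, and no measurement at hand bears on its cause.

Still open, from the compounds shown here alone, is how the step divides between the ring nitrogen and the exchange of methoxy for fluorine, since a single pair of compounds cannot separate the two, and how this position would respond to an amine, a carboxylic acid or a longer chain on the ring. Compound 2 and compound 3 differ from compound 1 in more than one place, which leaves the contribution of the group on the sulfonyl unread and gives no second context in which to test this change.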